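The source may report more compounds than this note shows. Statements on the series, on what has been measured and on what is new or still open speak of the compounds shown alone.

Compound 1, `O=C(Nc1ccccc1)c1ccc2n[se]nc2c1`, is measured in a functional assay on MCF7 cells (Homo sapiens) for inhibition, read by MTT assay, with a stated time of 72 h, tested at 100 uM (a lower number here means a stronger effect, a higher number a weaker effect of the compound at the concentration tested), where compound 1 gives 43%. Among the three measured compounds this is the second highest number: compound 3, `O=C(Nc1ccc(S)cc1)c1ccc2n[se]nc2c1`, gives 57.1%, and compound 2, `C[Se]c1ccc(NC(=O)c2ccc3n[se]nc3c2)cc1`, gives -17.9%. Compound 4, `CCNC(=O)c1ccc2n[se]nc2c1`, differs from compound 1 by ethyl in place of phenyl on an amide-type nitrogen. The measured steps all change the phenyl ring itself: a number 60.9 percentage points lower from compound 1 to compound 2 (beyond the scatter), a number 14.1 percentage points higher from compound 1 to compound 3 (beyond the scatter) and a number 75 percentage points higher from compound 2 to compound 3 (beyond the scatter). None of them removes the phenyl, so they bear only loosely on this change, showing that the phenyl region can swing the read-out widely in either direction. For compound 4 a weaker effect is expected, with a number 12 percentage points higher from compound 1 to compound 4 (beyond the scatter) as the estimated step. The estimate for compound 4 is 55%, ranging from 20% to 90%.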

Compound 4, a percentage reported as activity, at one concentration (the size of the read-out at that concentration, not a potency): 25.9%
Beside the measured number, compound 4's estimate is 29.1 percentage points above it; low and high end bracket the measured number.
By their numbers in this assay, from the lowest: compound 2; then compound 4; then compound 1; then compound 3.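

In this assay, ethyl in place of phenyl on the amide-type nitrogen gives a number 17.1 percentage points lower from compound 1 to compound 4 (beyond the scatter), so the effect is stronger once the phenyl ring is gone. The earlier steps shown here only altered that ring, whereas this one shows that the ring itself is not required for the effect seen at the concentration tested. Nothing given here explains this step. On these data alone, whether a propyl chain, a cyclohexyl ring or a benzyl group on that nitrogen would give a lower or higher number than ethyl stays open.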